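From pyridin-3-yl to pyridin-4-yl on compound 2

The source may hold more compounds than are shown below. What is called first, only, known or untested is meant among the compounds shown, and "the series" means these compounds.

Compound 1 `C1=C(/C=C/c2cccnc2)COc2ccccc21`: 75000 nM
Compound 2 `Clc1ccc2c(c1)C=C(/C=C/c1cccnc1)CO2`: 37500 nM

Both numbers come from an ADME assay on HeLa cells (Homo sapiens) for cytotoxicity, read by XTT assay, with a stated time of 3 days; on this read-out higher numbers stand for lower toxicity in this test and lower numbers for higher toxicity in this test. Within the data shown here, with only two compounds measured, compound 2 stands at 37500 nM, within the scatter of compound 1, its only neighbour on the scale.

Compound 3 `Clc1ccc2c(c1)C=C(/C=C/c1ccncc1)CO2` has not yet been measured. It differs from compound 2 in one group: pyridin-4-yl in place of pyridin-3-yl on a double-bonded chain carbon bound to a double-bonded chain carbon. Put simply, this is pyridin-4-yl in place of pyridin-3-yl on a double-bonded chain carbon bound to a double-bonded chain carbon, with the same atoms joined differently.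

Among the measured compounds shown here, no measured pair makes this swap. For the measured compounds named here, the one measured step, a 2.0-fold lower number from compound 1 to compound 2 (0.30 log units; within the scatter), is a different change, chloro in place of hydrogen on an aromatic carbon, so it offers only a weak guide. Starting from compound 2 at 37500 nM, no step beyond the scatter is expected in this assay, and no direction can be favoured. The expected step is no change at the digits printed from compound 2 to compound 3 (within the scatter). Compound 3 is estimated at 37500 nM, with an expected range from 16000 nM to 85000 nM.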

Compound 3, half-maximal cytotoxic concentration: 75000 nM
Beside the measured number, compound 3's estimate is 2.0-fold (0.30 log units) below it; the range from low to high includes it.
By their numbers in this assay, from the lowest: compounds 2, 1 and 3 (each within the scatter of the next).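

In this assay, placing pyridin-4-yl where pyridin-3-yl stood, on a double-bonded chain carbon bound to a double-bonded chain carbon, gives a 2.0-fold higher number from compound 2 to compound 3 (0.30 log units; within the scatter) and so does not stand out from the ordinary spread of repeat measurements. Among these compounds, this is the first information about this position, since the earlier pair shared pyridin-3-yl there and differed only by chloro in place of hydrogen on an aromatic carbon; the same atoms can now be joined differently at this place with no step beyond the scatter in this test. Nothing available explains this result or links it to any property of either group.

As far as these compounds go, whether pyridin-2-yl, a plain phenyl ring, or a ring carrying an amine or a carboxylic acid would keep the number within the same scatter remains open. From the compounds shown here alone, it is also open whether the swap from pyridin-3-yl to pyridin-4-yl would give a similar step on the core of compound 1, which has hydrogen in place of the chloro.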